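The source may report more compounds than this note shows. Statements on the series, on what has been measured and on what is new or still open speak of the compounds shown alone.

Measured so far in an assay on isolated protein for inhibition of malate dehydrogenase, mitochondrial (Sus scrofa), with stated times of 45 min and 30 min; on this read-out higher numbers stand for weaker inhibition and lower numbers for stronger inhibition:
- compound 1, `CS(=O)(=O)Nc1ccc(-c2nc3ccccc3o2)cc1`: > 63000 nM
- compound 2, `O=S(=O)(Nc1ccc(-c2nc3ccccc3o2)cc1)c1ccccc1O`: > 63000 nM

The value of compound 1 in this assay is a limit, not a number. The value of compound 2 in this assay is likewise a limit. Within the data shown here, the one step between measured compounds, a step that the two limits leave unreadable from compound 1 to compound 2, therefore cannot be read in size or direction. Among the measured compounds shown here, compound 2 stands at the same limit as the only other value shown; this is the limit of > 63000 nM in this assay, at which 2 of the 2 values shown sit.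

Compound 3, `Cc1ccccc1S(=O)(=O)Nc1ccc(-c2nc3ccccc3o2)cc1`, differs from compound 2 by methyl in place of hydroxy on an aromatic carbon of a six-membered aromatic ring of carbon only, ortho to a large group, which read one bond further out is 2-hydroxyphenyl to 2-methylphenyl. For the measured compounds named here, no measured step bears on this exchange; the only step, from compound 1 to compound 2, is unreadable. Nothing seen so far shows any compound of this core reaching a readable number, so the step that the limit leaves unreadable from compound 2 to compound 3 is expected to be small or absent beyond the scatter. Compound 3 is expected at about 100000 nM, range 30000 nM to 400000 nM, most likely again reported only as a limit.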

Compound 3, half-maximal inhibitory concentration: > 63000 nM
Compound 3: no number, only a limit; the forecaster's own chance of this, stated with the estimate: 85%; the middle value does not contradict the limit.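

In this assay compound 3 gives > 63000 nM, a limit and not a number. Among these compounds, no step among compound 1, compound 2 and compound 3 can be read in size or direction, as all three share one limit: the limit of > 63000 nM in this assay, at which 3 of the 3 values shown sit. The compounds shown leave open whether any group on the sulfonyl sulfur of the shared core gives a readable value.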